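This account rests on a few compounds, and the source may have more. Where it says the series, first, only, none or still open, it means among the compounds named here.

Working notes on a small chalcone series measured for cytotoxicity.

Compound 1 `COc1cc(O)cc(O)c1C(=O)/C=C/c1ccc(O)cc1` is the parent of the set. In a functional assay on HeLa cells (Homo sapiens) for cytotoxicity, read by MTT assay (a higher number here means a weaker inhibitor, a lower number a stronger inhibitor), compound 1 gives 5200 nM, the lower of the two numbers recorded so far. Among the measured compounds shown here, the only other measured member, compound 2 `COc1cc(O)c(C(=O)/C=C/c2ccc(O)cc2)c(O)c1CC=C(C)C`, differs from compound 1 in more than one place, so no single-change step can be drawn between them; in this assay compound 2 gives 28300 nM, a number well beyond the scatter of the value for compound 1. Within what has been measured, compound 1 therefore stands as the stronger of the two, and nothing more can be said about the origin of that gap.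

The next member, compound 3 `COc1cc(O)cc(O)c1C(=O)/C=C/c1ccc(O)c(O)c1`, is compared with compound 1 alone. The change is hydroxy in place of hydrogen on an aromatic carbon, placed ortho to a hydroxy group and meta to a large group on the same ring. For the measured compounds named here, no measured pair shows the effect of this change in this assay. The step from compound 1 is expected to be small, if anything toward a lower number, and likely within the scatter: a 1.3-fold lower number from compound 1 to compound 3 (0.11 log units; within the scatter). For compound 3 the estimated value in this assay is 4000 nM, with a range from 1500 nM to 12000 nM.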

Compound 3, half-maximal inhibitory concentration: 14800 nM
Estimate against measurement, compound 3: 3.7-fold (0.57 log units) below, and the stated range ends below it.
By their numbers in this assay, from the lowest: compound 1; then compounds 3 and 2 (each within the scatter of the next).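

Among the compounds shown here, this is the first single-change step: in this assay, hydroxy in place of hydrogen on an aromatic carbon, ortho to a hydroxy group and meta to a large group, gives a 2.8-fold higher number from compound 1 to compound 3 (0.45 log units; beyond the scatter). The step is modest, but it lies beyond the scatter, so this position of the core of compound 1 is not indifferent to the change, and here the added hydroxy goes with a weaker inhibitor rather than a stronger one. Nothing in the data at hand bears on what lies behind this rise.

On these data alone, a single group at a single position gives only one point, so it remains open whether an amine, a fluorine atom or a carboxylic acid on the same aromatic carbon would move the number in the same direction or by a similar amount. As far as these compounds go, it is also open whether hydroxy in place of hydrogen would give a comparable step on another aromatic carbon of the core, or on the core of compound 2, which differs from compound 1 in more than one place.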